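The compounds below may be only part of what the source reports. "The series", "measured", "known", "first", "only" and "open" are said of these compounds alone.

Compound 2, `COc1ccc(/C=C\c2cc(OC)c(OC)c(OC)c2)cc1OCc1ccc(CN2CC(C(=O)O)C2)cc1`, belongs to a set of stilbene-derived structures whose shared core is extended by an amino acid or cyclic acid at a saturated chain carbon bound to an aromatic carbon. In a functional assay on HepG2 cells (Homo sapiens) for antiproliferative activity, read by CCK-8 assay, with a stated time of 48 h (on this read-out higher numbers stand for weaker inhibition and lower numbers for stronger inhibition), compound 2 reaches only the limit of the assay, > 10000 nM. Its neighbour compound 1, `COc1ccc(/C=C\c2cc(OC)c(OC)c(OC)c2)cc1OCc1ccc(CN[C@H](C(=O)O)[C@H](C)O)cc1`, carries the (1-carboxy-2-hydroxypropyl)amino group in the same place. In this assay compound 1 likewise gives only the limit, > 10000 nM. The step from compound 1 to compound 2 is therefore a step that the two limits leave unreadable from compound 1 to compound 2, as both sit at the limit of > 10000 nM in this assay, at which 2 of the 2 values shown sit. Compound 3, `COc1ccc(/C=C\c2cc(OC)c(OC)c(OC)c2)cc1OCc1ccc(CN2CC[C@@H](C(=O)O)C2)cc1`, continues the series with 3-carboxypyrrolidin-1-yl in place of 3-carboxyazetidin-1-yl on a saturated chain carbon bound to an aromatic carbon. For the measured compounds named here, no measured step resolves how ring size at this position moves the read-out, since the only comparable step is unreadable. Compound 3 is thus expected to remain at or near the assay limit, with the estimated step that the limit leaves unreadable from compound 2 to compound 3 carrying little information. The expected value of compound 3 is 15000 nM, within 5000 nM to 50000 nM.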

Compound 3, half-maximal inhibitory concentration: 2300 nM
The estimate for compound 3 lay 6.5-fold (0.81 log units) above the measured number; the whole stated range lies above it.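

In this assay, the position on a saturated chain carbon bound to an aromatic carbon proves responsive to the group placed there: 3-carboxypyrrolidin-1-yl in place of 3-carboxyazetidin-1-yl gives an at least 4.3-fold lower number from compound 2 to compound 3 (0.63 log units; beyond the scatter). The same group in place of (1-carboxy-2-hydroxypropyl)amino gives an at least 4.3-fold lower number from compound 1 to compound 3 (0.63 log units; beyond the scatter), and since all three compounds carry a carboxylic acid, that group alone does not separate them. Both steps start from a limit, so each gives only a smallest size and not a true one: the limit of > 10000 nM in this assay, at which 2 of the 3 values shown sit.

On these data alone, whether 3-carboxypiperidin-1-yl would extend or reverse the change from 3-carboxyazetidin-1-yl to 3-carboxypyrrolidin-1-yl remains open. Also open, as far as these compounds go, is how a plain pyrrolidin-1-yl without the carboxylic acid, or a primary amide in place of that acid, would read out in this assay.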